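Fused heteroaryl anilines: dropping the butoxy group

The compounds below may be only part of what the source reports. "The series", "measured", "known", "first", "only" and "open" are said of these compounds alone.

Measured so far in an assay on mitochondria from L6 cells (Rattus norvegicus) for activation, with a stated time of 90 min; on this read-out lower numbers stand for an effect already at smaller amounts and higher numbers for an effect only at larger amounts of compound:
Compound 1 `COc1cc(OC(F)(F)F)ccc1Nc1nc2nonc2nc1O`: 3800 nM
Compound 2 `CCCCOc1ccc(Nc2nc3nonc3nc2O)cc1`: 3700 nM
Compound 3 `Oc1nc2nonc2nc1Nc1cccc(OCc2ccc(C(F)(F)F)cc2)c1`: 3000 nM

All three numbers for compound 1, compound 2 and compound 3 lie within the scatter of one another, so no order among them can be read. Compound 2 stands with the second highest number, closest to compound 1 and furthest from compound 3, both gaps within the scatter.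

Compound 4 `Oc1nc2nonc2nc1Nc1ccccc1` differs from compound 2 by hydrogen in place of butoxy on an aromatic carbon. Among the measured compounds shown here, no step between measured compounds tests this change, so the expectation rests on the general range of the series alone. A modest rise in the number, at the edge of the scatter, is expected: a 1.9-fold higher number from compound 2 to compound 4 (0.28 log units; within the scatter). Compound 4 is expected at 7000 nM, with a range of 2500 nM to 20000 nM.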

Compound 4, half-maximal effective concentration: 66700 nM
Estimate against measurement, compound 4: 9.5-fold (0.98 log units) below, outside the stated range (above it).
By their numbers in this assay, from the lowest: compounds 3, 2 and 1 (each within the scatter of the next); then compound 4.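

In this assay, among the compounds shown here, hydrogen in place of butoxy on the aromatic carbon gives an 18-fold higher number from compound 2 to compound 4 (1.26 log units; beyond the scatter), the only step and one beyond the scatter, so the group at this place matters. The earlier compounds shown here, all within the scatter of one another, could not show this. Nothing measured bears on why the butoxy group counts here. Open, going by these compounds, is whether ethoxy, a longer chain or an amine at this place would hold the number of compound 2. Also open, on these data alone, is whether the ether oxygen alone or the whole butoxy chain carries the step.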